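The source may report more compounds than this note shows. Statements on the series, on what has been measured and on what is new or still open speak of the compounds shown alone.

Of the compounds shown here, three built on one shared core have been measured in an assay on HEK293 cells for positive allosteric modulation of metabotropic glutamate receptor 2 (Rattus norvegicus), read by thallium flux, with a stated time of 2.5 min; a higher number here means a larger maximal response, a lower number a smaller maximal response. Compound 1 `Cc1c(OCCCCOCOc2ccc(C(=O)O)cc2)ccc(C(=O)CC2CCCC2)c1O` gives 95.4%. Among the measured compounds shown here, compound 2 `Cc1c(OCCCCOc2ccc(C(=O)O)c(Cl)c2)ccc(C(=O)CC2CCCC2)c1O` gives 80.8%, and the one measured step, a number 14.6 percentage points lower from compound 1 to compound 2 (beyond the scatter), concerns the ring at the far end of the chain from the ketone. Compound 3 `Cc1cc(C(=O)O)ccc1OCCCCOc1ccc(C(=O)C(C)C)c(O)c1C` gives 76.9%, the lowest of the three numbers; its gap to compound 2 lies within the scatter, while compound 1 stands beyond the scatter above it.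

Compound 4 `Cc1cc(C(=O)O)ccc1OCCCCOc1ccc(C(=O)CC2CCCC2)c(O)c1C` has not yet been measured. It differs from compound 3 in one place: cyclopentylmethyl in place of isopropyl on a carbonyl carbon. For the measured compounds named here, no measured step touches this carbonyl carbon, so the step of a number 14.6 percentage points lower from compound 1 to compound 2 (beyond the scatter) offers no direct guide. What can be said is that compound 1 and compound 2 both carry cyclopentylmethyl on the carbonyl carbon, and compound 1 with 95.4% sits beyond the scatter above compound 3, whereas compound 2 with 80.8% sits within the scatter of it. On that slim basis a small rise is expected, a number 8.1 percentage points higher from compound 3 to compound 4 (within the scatter), though it may well stay within the scatter. Compound 4 is therefore estimated at 85%, with a range from 70% to 100%.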

Compound 4, largest response reached (reported as percent of maximum), in percent of the reference or control that the assay uses: 84.6%
Beside the measured number, compound 4's estimate is 0.4 percentage points above it; measured number inside the range.
By their numbers in this assay, from the lowest: compounds 3, 2 and 4 (each within the scatter of the next); then compound 1.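

Among the compounds shown here, on the carbonyl carbon, cyclopentylmethyl (6 heavy atoms, with a five-membered ring) in place of isopropyl (3 heavy atoms, no ring) gives a number 7.7 percentage points higher from compound 3 to compound 4 (within the scatter) in this assay and so offers the first direct reading at this position: the two groups cannot be told apart by this maximal response. The far ring can now be compared as well, and 4-carboxy-2-methylphenyl in place of 4-carboxy-3-chlorophenyl on the oxygen gives a number 3.8 percentage points higher from compound 2 to compound 4 (within the scatter) and leaves those two rings equally indistinguishable. Only the change from (4-carboxyphenoxy)methyl to 4-carboxy-2-methylphenyl on that oxygen gives a number 10.8 percentage points lower from compound 1 to compound 4 (beyond the scatter) and stands clear of the scatter, a modest step that matches the one already seen with the chloro ring, so both rings attached directly to the oxygen read below the (4-carboxyphenoxy)methyl group.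

Going by these compounds, whether a much longer chain on the carbonyl carbon, or an amine in place of the carboxylic acid on the far ring, would keep this response remains open. The reason behind any of these steps also stays open, since nothing shown here bears on it.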